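A few compounds are considered here, and "the series" means these few. Any claim that something is new, unique, unknown or untested is made for them only; others in the source may bear on it.

Measured so far in an ADME assay on ORL8 cells (Homo sapiens) for cytotoxicity, read by WST assay, with a stated time of 72 h; on this read-out lower numbers stand for higher toxicity in this test and higher numbers for lower toxicity in this test:
compound 1, `Nc1ccn([C@@H]2O[C@](F)(CO)[C@H](F)[C@H]2O)c(=O)n1`, gives 36000 nM.
compound 2, `Nc1ncnc2c1ncn2[C@@H]1O[C@@](F)(CO)[C@H](F)[C@H]1O`, gives > 100000 nM, which is a limit of the test and not a number.

Among the measured compounds shown here, compound 2 thus stands only at the limit of > 100000 nM in this assay, at which 1 of the 2 values shown sits; no number exists for it, so no step between the two measured compounds can be sized, and what compound 1 shows is said of compound 1 alone. Compound 3, `Nc1ncnc2c1ncn2[C@@H]1O[C@@](F)(CO)[C@@H](F)[C@@H]1O`, is the next member to be read in this assay. How it differs from compound 2: the two compounds have the same atoms and bonds and differ only in configuration as drawn: 2 of 4 stereo elements differ; a stereocentre at a saturated ring carbon is drawn R in compound 2 and S in compound 3; a stereocentre at a saturated ring carbon is drawn S in compound 2 and R in compound 3. Same atoms, same bonds; only two stereocentres at saturated ring carbons are drawn the other way round. With compound 2 known only as a limit, the change from compound 2 to compound 3 cannot be anchored on a measured number, and nothing in the two measured values speaks for a move in either direction. The expectation is a step of a number no higher from compound 2 to compound 3 (the limit leaves the size open), none beyond the scatter. Compound 3 is therefore expected at about 100000 nM, between 40000 nM and 250000 nM, most probably again reported only as a limit.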

Compound 3, half-maximal cytotoxic concentration: > 200000 nM
Compound 3: only a limit was reported; the forecaster's own chance of this, stated with the estimate: 70%; at least 2.0-fold (0.30 log units) between middle value and limit.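

In this assay, among the compounds shown here, compound 2 and compound 3 are both reported only as limits of the test and not as numbers, so no step between them can be read. The compounds shown leave open whether redrawing the two stereocentres at saturated ring carbons shifts the half-maximal cytotoxic concentration at all.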